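This account rests on a few compounds, and the source may have more. Where it says the series, first, only, none or still open, it means among the compounds named here.

Compound 2 `Cc1ccc(C(=O)Nc2cc(CN3CCN(C)CC3)cc(C(F)(F)F)c2)cc1-c1ccc2cn[nH]c2c1` gives 4.7 nM in an assay on isolated protein for inhibition of Discoidin domain-containing receptor 2 (Homo sapiens), read by ELISA, with a stated time of 60 min (on this read-out lower numbers stand for stronger inhibition and higher numbers for weaker inhibition), and stands at the lowest of the two numbers at hand, while compound 1 `Cc1ccc(C(=O)Nc2cccc(CN3CCN(C)CC3)c2)cc1-c1ccc2cn[nH]c2c1` gives 75.9 nM in this assay. For the measured compounds named here, the single step between measured compounds, a 16-fold lower number from compound 1 to compound 2 (1.21 log units; beyond the scatter), belongs to trifluoromethyl in place of hydrogen on an aromatic carbon and is large, but it concerns a different place from the one changed here. Compound 3 `Cc1ccc(C(=O)Nc2cc(CN3CCN(C4CCCC4)CC3)cc(C(F)(F)F)c2)cc1-c1ccc2cn[nH]c2c1` differs from compound 2 by cyclopentyl in place of methyl on an amine nitrogen in a ring. Going by the values given here, no measured step touches the substituent on the amine nitrogen in the ring, so nothing in the data points to a direction for this change, and the step is expected to lie within the scatter, a 1.2-fold higher number from compound 2 to compound 3 (0.07 log units; within the scatter). For compound 3 the estimate in this assay is 5.5 nM, with an expected range from 1.5 nM to 20 nM.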

Compound 3, half-maximal inhibitory concentration: 7 nM
For compound 3 the middle estimate is 1.3-fold (0.10 log units) below the measured one; the range from low to high includes it.
By their numbers in this assay, from the lowest: compounds 2 and 3 (each within the scatter of the next); then compound 1.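

In this assay, for the compounds shown here, the substituent on the amine nitrogen in the ring is varied for the first time, and cyclopentyl in place of methyl gives a 1.5-fold higher number from compound 2 to compound 3 (0.17 log units; within the scatter). Thus, in this pair, this position takes five carbons and a five-membered ring of carbon only in place of a single carbon, and the two numbers cannot be told apart, whereas the only earlier step concerned trifluoromethyl at another place. No measurement given here bears on why the numbers of this pair stay together.

The compounds shown leave open whether cyclopentyl would behave the same way on the core of compound 1, which lacks trifluoromethyl. They also leave open how a hydroxyethyl group, an acetyl group or a carboxylic acid on this nitrogen would read, since both groups compared here contain carbon only.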